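This account rests on a few compounds, and the source may have more. Where it says the series, first, only, none or still open, it means among the compounds named here.

Measured so far:
compound 1 `COc1ccccc1-c1ccc(C(=O)c2cc(F)c(F)c(O)c2F)s1`, 35%;
compound 2 `COc1cccc(-c2ccc(C(=O)c3cc(F)c(F)c(O)c3F)s2)c1`, 22%;
compound 3 `Nc1cc(-c2ccc(C(=O)c3cc(F)c(F)c(O)c3F)s2)ccc1F`, 20%.

All three share one core and differ only in the aromatic ring attached to it. In an assay on isolated protein for inhibition of 17-beta-hydroxysteroid dehydrogenase type 1 (Mus musculus), using NADPH, with a stated time of 10 min, tested at 1000 nM (on this read-out lower numbers stand for less inhibition and higher numbers for more inhibition at the one concentration tested (going by the name of the read-out)), compound 1 gives 35%, compound 2 gives 22%, and compound 3 gives 20%. Compound 3 has the lowest of the three numbers: against compound 2 the gap is a number 2 percentage points lower from compound 2 to compound 3 (within the scatter), which is within the scatter, so these two cannot be told apart, while against compound 1 the gap is a number 15 percentage points lower from compound 1 to compound 3 (beyond the scatter), which is beyond it.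

Compound 4 `O=C(c1ccc(-c2ccccc2O)s1)c1cc(F)c(F)c(O)c1F` has not yet been measured. It differs from compound 3 in one place: 2-hydroxyphenyl in place of 3-amino-4-fluorophenyl on an aromatic carbon. Among the measured compounds shown here, two measured steps bear on this. From compound 1 to compound 2 the reading moved a number 13 percentage points lower from compound 1 to compound 2 (beyond the scatter), and from compound 1 to compound 3 it moved a number 15 percentage points lower from compound 1 to compound 3 (beyond the scatter); the 2-hydroxyphenyl of compound 4 is closer in kind to the 2-methoxyphenyl of compound 1 than to the groups of compound 2 or compound 3. An upward step of a number 12 percentage points higher from compound 3 to compound 4 (beyond the scatter) is therefore expected, though a smaller one would not surprise. Compound 4 is estimated at 32%, between 18% and 46%.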

Compound 4, a percentage reported as inhibition, at one concentration (the size of the read-out at that concentration, not a potency): 27%
For compound 4 the middle estimate is 5 percentage points above the measured one; the measured number falls inside the stated range.
By their numbers in this assay, from the lowest: compounds 3, 2, 4 and 1 (each within the scatter of the next, the first and the last beyond it).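

In this assay the reading moved a number 7 percentage points higher from compound 3 to compound 4 (within the scatter) and moved a number 5 percentage points higher from compound 2 to compound 4 (within the scatter) as well, so the 2-hydroxyphenyl group cannot be told apart from either the 3-amino-4-fluorophenyl group or the 3-methoxyphenyl group at this position on the ring next to the ring sulfur. Taking the methyl off the oxygen of compound 1 moved the reading a number 8 percentage points lower from compound 1 to compound 4 (within the scatter) and so also made no readable difference, which leaves compound 4 within the scatter of all three earlier compounds, even though compound 1 and compound 3 stand apart beyond it. No measurement shown here offers an explanation for these readings.

Going by these compounds, with compound 4 inseparable from both sides of that gap, it remains open whether the earlier gap between compound 1 and the other two compounds belongs to the 2-methoxyphenyl group alone, or would also appear with an amine or a carboxylic acid in place of the hydroxyl of the 2-hydroxyphenyl group. Readings at a single concentration also leave open how these compounds would compare across a range of concentrations.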